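The source may report more compounds than this note shows. Statements on the series, on what has been measured and on what is new or still open speak of the compounds shown alone.

Measured compounds in a physicochemical assay for lipophilicity; a higher number here means a more lipophilic compound, a lower number a more polar compound:
- compound 1, `COc1cccc(CNCc2c(-c3nnc(SC(C)C)n3-c3ccccc3)n(C)c3ccccc23)c1`: compound 1 gives 6.27
- compound 2, `CC(C)Sc1nnc(-c2c(CNc3nc4ccccc4[nH]3)c3ccccc3n2C)n1-c1ccccc1`: compound 2 gives 5.94
- compound 3, `COc1ccc(CNCc2c(-c3nnc(SC(C)C)n3-c3ccccc3)n(C)c3ccccc23)cc1`: compound 3 gives 6.27

Compound 3 stands level with compound 1, the two together being the highest of the three numbers; the step of no change at the digits printed from compound 1 to compound 3 (within the scatter) lies within the scatter, whereas the step of a number 0.33 log units higher from compound 2 to compound 3 (beyond the scatter) lies beyond it. Compound 4, `CC1CN(Cc2c(-c3nnc(SC(C)C)n3-c3ccccc3)n(C)c3ccccc23)CC(C)O1`, has not yet been measured in this assay. Its difference from compound 3 is 2,6-dimethylmorpholin-4-yl in place of (4-methoxybenzyl)amino on a saturated chain carbon bound to an aromatic carbon. Of the measured steps, a number 0.33 log units higher from compound 2 to compound 3 (beyond the scatter) and a number 0.33 log units lower from compound 1 to compound 2 (beyond the scatter) each exchange the group on the amine nitrogen, while no change at the digits printed from compound 1 to compound 3 (within the scatter) only moves a methoxy group on the ring; none of them replaces the whole amine with a ring as here, so they bear on this step only loosely and leave the expectation uncertain. Given what leaves and what enters under the counted difference, a modest drop beyond the scatter is expected, a number 0.67 log units lower from compound 3 to compound 4 (beyond the scatter). Compound 4 is therefore estimated at 5.6, in the range 5 to 6.2.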

Compound 4, partition coefficient: 5.13
The estimate for compound 4 lay 0.47 log units above the measured number; measured number inside the range.
By their numbers in this assay, from the lowest: compound 4; then compound 2; then compounds 1 and 3 (each within the scatter of the next).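

In this assay, among the compounds shown here, the earlier compounds only exchanged the group on the amine nitrogen or moved a methoxy group, whereas putting 2,6-dimethylmorpholin-4-yl on the saturated chain carbon bound to an aromatic carbon gives a number 1.14 log units lower from compound 3 to compound 4 (beyond the scatter) and, of the same size, a number 1.14 log units lower from compound 1 to compound 4 (beyond the scatter) as well as a number 0.81 log units lower from compound 2 to compound 4 (beyond the scatter) for the third comparison. This position can therefore shift the number further than any exchange among the earlier amine groups, and compound 4 now stands lowest of the four. Nothing measured here shows which part of this change accounts for the drop.

The plain morpholine ring without its two methyl groups would show what those methyl groups contribute. Piperidine, with a ring carbon in place of the ring oxygen, would do the same for that oxygen.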